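Swapping diisopropylamino for methoxymethoxy on the shared core

This account rests on a few compounds, and the source may have more. Where it says the series, first, only, none or still open, it means among the compounds named here.

Values in a functional assay on A549 cells (Homo sapiens) for antiproliferative activity, read by MTT assay, with a stated time of 48 h; on this read-out higher numbers stand for weaker inhibition and lower numbers for stronger inhibition:
- compound 1 `CC(C)=CCC[C@]1(C)/C=C/[C@@H](OC(=O)C=C(C)C)[C@](C)(O)/C=C/C(=O)/C(CCl)=C\C1`: 150 nM
- compound 2 `CC(C)=CCC[C@]1(C)/C=C/[C@@H](OC(=O)C=C(C)C)[C@](C)(O)/C=C/C(=O)/C(CN(C(C)C)C(C)C)=C\C1`: 650 nM

Compound 2 holds the higher of the two numbers, at 650 nM. Still unmeasured is compound 3 `COCOC/C1=C/C[C@](C)(CCC=C(C)C)/C=C/[C@@H](OC(=O)C=C(C)C)[C@](C)(O)/C=C/C1=O`, which has methoxymethoxy in place of diisopropylamino on a saturated chain carbon bound to a double-bonded ring carbon. Going by the values given here, only one measured step bears on this carbon: a 4.3-fold higher number from compound 1 to compound 2 (0.64 log units; beyond the scatter), with diisopropylamino in place of chloro. That step is modest and lies beyond the scatter. Among the compounds with values here, no measured compound carries methoxymethoxy, so this single step sets only a rough scale. The expected change is a 1.6-fold lower number from compound 2 to compound 3 (0.21 log units; within the scatter), a modest move towards a lower number in this assay, though the range also allows no real change. For compound 3 the estimate is 400 nM, with an expected range of 130 nM to 1200 nM.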

Compound 3, half-maximal inhibitory concentration: 2980 nM
Compound 3: middle estimate off by 7.5-fold (0.87 log units), on the low side; the whole stated range lies below it.
By their numbers in this assay, from the lowest: compound 1; then compound 2; then compound 3.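

In this assay the methoxymethoxy group on this saturated chain carbon bound to a double-bonded ring carbon does not recover what was lost on leaving chloro; it moves further the same way (a 4.6-fold higher number from compound 2 to compound 3 (0.66 log units; beyond the scatter)). Against chloro the step is larger (a 20-fold higher number from compound 1 to compound 3 (1.30 log units; beyond the scatter)), and between compound 2 and compound 3 the group with fewer heavy atoms, methoxymethoxy with 4 against 7 for diisopropylamino, gives the higher number. Nothing available accounts for this order of the three groups.

From the compounds shown here alone, whether any replacement for chloro at this carbon stays close to compound 1 remains open, for example a hydroxyl, a fluoro or a smaller amine such as dimethylamino. Going by these compounds, whether the order of these three groups holds in other cell lines is also open.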